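Hydroxy to Methoxy in a Cytotoxicity Series

The source may report more compounds than this note shows. Statements on the series, on what has been measured and on what is new or still open speak of the compounds shown alone.

Measured compounds:
compound 1, `COc1cc(/C=C2\CCC/C(=C\c3ccc([N+](=O)[O-])cc3)C2=O)ccc1O`, in a functional assay on HPC cells (Homo sapiens) for cytotoxicity (on this read-out higher numbers stand for lower toxicity in this test and lower numbers for higher toxicity in this test), gives > 400000 nM, which is a limit of the assay.
compound 2, `COc1ccc(/C=C2\CCC/C(=C\c3ccc([N+](=O)[O-])cc3)C2=O)cc1OC`, gives 82000 nM.
compound 3, `O=C1/C(=C/c2ccc(O)cc2)CCC/C1=C\c1ccc([N+](=O)[O-])cc1`, gives > 400000 nM, again a limit of the assay.

Three compounds share a core, and only the substituents on one aromatic ring differ. Compound 1 and compound 2 differ by methyl in place of hydrogen on an oxygen on an aromatic ring, and this change brings an at least 4.8-fold lower number from compound 1 to compound 2 (0.68 log units; beyond the scatter). Compound 1 and compound 3 differ in their cores by hydrogen in place of methoxy on an aromatic carbon, but the step is a step that the two limits leave unreadable from compound 1 to compound 3, since both values sit at the limit of > 400000 nM in this assay, at which 2 of the 3 values shown sit.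

Compound 4, `COc1ccc(/C=C2\CCC/C(=C\c3ccc([N+](=O)[O-])cc3)C2=O)cc1`, is not yet measured. It stands to compound 3 exactly as compound 2 stands to compound 1: the change is methyl in place of hydrogen on an oxygen on an aromatic ring, the same change at the same place, and the only structural difference between the two pairs is the one already described between the cores of compound 1 and compound 3.

Compound 3 sits at the limit, so the step to compound 4 is expected to read an at least 4.0-fold lower number from compound 3 to compound 4 (0.60 log units; beyond the scatter), resting on the earlier change from compound 1 to compound 2 that gave an at least 4.8-fold lower number from compound 1 to compound 2 (0.68 log units; beyond the scatter). For compound 4 the estimate is therefore 100000 nM, with a range from 30000 nM to 400000 nM.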

Compound 4, half-maximal cytotoxic concentration: > 400000 nM
Compound 4 gave a limit, no number (the forecaster's own chance of this, stated with the estimate: 35%); at least 4.0-fold (0.60 log units) between middle value and limit.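

In this assay compound 4 gives > 400000 nM, which is a limit of the assay. Methyl in place of hydrogen on an oxygen on an aromatic ring brought an at least 4.8-fold lower number from compound 1 to compound 2 (0.68 log units; beyond the scatter), but the same change yields no readable size in the core of compound 3, and neither the step from compound 3 to compound 4 nor the step from compound 1 to compound 4 can be read, because both ends of each step sit at the same limit: the limit of > 400000 nM in this assay, at which 3 of the 4 values shown sit.

For the compounds shown here, the one readable new step is an at least 4.8-fold higher number from compound 2 to compound 4 (0.68 log units; beyond the scatter), which ties the number of compound 2 to the methoxy that compound 4 lacks, so the series shows that the change does not bring compound 4 to a measured number, yet it does not show that the change has no effect in this core, nor that it has the same effect in both cores.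

The compounds shown leave open how far compound 1, compound 3 and compound 4 lie past the limit in this assay. They also leave open whether an ethoxy or an amine in place of the hydroxy, or a carboxylic acid in place of the nitro group, would give a number within the range of this read-out on the core of compound 3.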